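The compounds below may be only part of what the source reports. "The series", "measured", "known", "first", "only" and "open" are said of these compounds alone.

Going by the values given here, compound 1 `CCCc1ccc(N2C(=O)NC3(CSC4=C3C(=O)c3ncccc3C4=O)C2=O)cc1` gives the lowest number of the two measured so far in a functional assay on CCRF-SB cells (Homo sapiens) for antiproliferative activity, read by MTT assay, with a stated time of 96 h (a higher number here means a weaker inhibitor, a lower number a stronger inhibitor), at 2 nM. Among the compounds with values here, its only neighbour, compound 2 `O=C1NNC(=O)C2(CSC3=C2C(=O)c2ncccc2C3=O)N1`, gives 48 nM in this assay, a gap beyond the usual scatter. Compound 3 `O=C1NC(=O)C2(CSC3=C2C(=O)c2ncccc2C3=O)N1` differs from compound 1 in one place: hydrogen in place of 4-propylphenyl on an amide-type nitrogen in a ring. Within the data shown here, no measured pair shows this same change, so its effect cannot be read from the data directly. The expected step is a 20-fold higher number from compound 1 to compound 3 (1.30 log units; beyond the scatter), toward weaker inhibition. Compound 3 is therefore expected to give about 40 nM in this assay, with a range from 8 nM to 200 nM.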

Compound 3, half-maximal inhibitory concentration: 150 nM
For compound 3 the middle estimate is 3.8-fold (0.57 log units) below the measured one, within the range that was stated.
By their numbers in this assay, from the lowest: compound 1; then compound 2; then compound 3.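

Putting hydrogen in place of 4-propylphenyl on the amide-type nitrogen in the ring gives a 75-fold higher number from compound 1 to compound 3 (1.88 log units; beyond the scatter) in this assay, so this position strongly affects the read-out. The group is not essential for activity, though: without it, compound 3 still gives 150 nM. Nothing available explains the size of this step. The compounds shown leave open whether the whole 4-propylphenyl group is needed, or only part of it. A plain phenyl ring or a short chain such as methyl on this nitrogen could separate the contribution of the ring from that of the propyl chain.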